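One more methoxy on compound 2

The source may report more compounds than this note shows. Statements on the series, on what has been measured and on what is new or still open speak of the compounds shown alone.

- compound 1 `COc1ccc(C(=O)n2c(-c3cn(C)c4ccccc34)nc3ccccc32)cc1OC`: 10200 nM
- compound 2 `COc1ccc(C(=O)n2c(-c3cn(C)c4ccc(Br)cc34)nc3ccccc32)cc1`: 19200 nM

In a functional assay on MCF7 cells (Homo sapiens) for inhibition, read by MTT assay, with a stated time of 24 h (on this read-out lower numbers stand for stronger inhibition of growth and higher numbers for weaker inhibition of growth), compound 2 gives 19200 nM and compound 1 gives 10200 nM and these two numbers lie within the usual scatter of each other, so the data do not separate compound 2 from compound 1.

Compound 3 `COc1ccc(C(=O)n2c(-c3cn(C)c4ccc(Br)cc34)nc3ccccc32)cc1OC` comes from compound 2 by a single change methoxy in place of hydrogen on an aromatic carbon and this methoxy, in place of hydrogen on an aromatic carbon, stands ortho to a methoxy group and turns 4-methoxyphenyl to 3,4-dimethoxyphenyl.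

Going by the values given here, no pair of measured compounds shows this change alone, so the size of the step has not been seen directly. Compound 1 at 10200 nM already carries 3,4-dimethoxyphenyl and offers the only hint, though it differs from compound 3 elsewhere. In this assay a step no larger than the scatter is therefore expected, with any drift toward a lower number. The expected move is a 1.5-fold lower number from compound 2 to compound 3 (0.17 log units; within the scatter) and it remains an estimate. The estimate for compound 3 is 13000 nM (expected range 6000 nM to 28000 nM).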

Compound 3, concentration for 50% growth inhibition: 11300 nM
For compound 3 the middle estimate is 1.2-fold (0.06 log units) above the measured one, and the stated range covers the measured number.
By their numbers in this assay, from the lowest: compounds 1, 3 and 2 (each within the scatter of the next).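

In this assay, the methoxy that turns 4-methoxyphenyl into 3,4-dimethoxyphenyl gives a 1.7-fold lower number from compound 2 to compound 3 (0.23 log units; within the scatter) on a background that carries the bromo, so this change can now be read directly, and its size cannot be told apart from repeat-measurement noise. Compound 3 also isolates the bromo in place of hydrogen on an aromatic carbon, giving a 1.1-fold higher number from compound 1 to compound 3 (0.04 log units; within the scatter) on a background that carries 3,4-dimethoxyphenyl, and this single change is also too small to separate its two compounds. No independent measurement bears on either result.

On these data alone, the three compounds show only hydrogen or methoxy at the position of the new group, so it remains open how a hydroxyl, an amine, a carboxylic acid or a longer chain such as butoxy would read there. For the other change, only bromo is shown in place of hydrogen, which leaves open whether chloro, fluoro or an amine at that carbon would give a step beyond the scatter.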